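Para substituent swap on the aryl group: methoxy to fluoro

A few compounds are considered here, and "the series" means these few. Any claim that something is new, unique, unknown or untested is made for them only; others in the source may bear on it.

Measured compounds in a functional assay on K562 cells (Homo sapiens) for inhibition, read by sulforhodamine B assay, with a stated time of 48 h, tested at 10 uM; a lower number here means less inhibition, a higher number more inhibition at the concentration tested (going by the name of the read-out):
compound 1, `Brc1cn2ccnc2c(-c2ccc3ncn(C4CCCCC4)c3c2)n1`, 18%
compound 2, `c1ccc(-c2cn3ccnc3c(-c3ccc4ncn(C5CCCCC5)c4c3)n2)cc1`, 70.6%
compound 3, `COc1ccc(-c2cn3ccnc3c(-c3ccc4ncn(C5CCCCC5)c4c3)n2)cc1`, 92%

Compound 3 stands highest of the three; the nearest is compound 2, and the step of a number 21.4 percentage points higher from compound 2 to compound 3 (beyond the scatter) is beyond the scatter, while the gap to compound 1, the step of a number 74 percentage points higher from compound 1 to compound 3 (beyond the scatter), is large. Compound 4, `Fc1ccc(-c2cn3ccnc3c(-c3ccc4ncn(C5CCCCC5)c4c3)n2)cc1`, is not yet measured. The change from compound 3 is fluoro in place of methoxy on an aromatic carbon.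

Among the measured compounds shown here, the one measured step that bears on this change is the methoxy-for-hydrogen step a number 21.4 percentage points higher from compound 2 to compound 3 (beyond the scatter), which shows that what stands on that aromatic carbon moves the read-out by a modest amount. Fluoro is neither methoxy nor hydrogen, so compound 4 is expected to fall between compound 2 and compound 3 in this assay, most likely nearer the lower of the two. The expected step is a number 16 percentage points lower from compound 3 to compound 4 (beyond the scatter). For compound 4 the estimate in this assay is 76%, within a range from 58% to 94%.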

Compound 4, a percentage reported as inhibition, at one concentration (the size of the read-out at that concentration, not a potency): 24.7%
Compound 4: the middle estimate sits 51.3 percentage points above what was measured; the whole stated range lies above it.
By their numbers in this assay, from the lowest: compounds 1 and 4 (each within the scatter of the next); then compound 2; then compound 3.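

In this assay, the group on this aromatic carbon, para to a large group, matters far more than the methoxy-for-hydrogen step suggested: fluoro gives a number 67.3 percentage points lower from compound 3 to compound 4 (beyond the scatter) and also a number 45.9 percentage points lower from compound 2 to compound 4 (beyond the scatter), so it lies outside the span of hydrogen and methoxy rather than inside it. An aryl group in place of bromo therefore does not carry the read-out by itself, since the change to 4-fluorophenyl reads a number 6.7 percentage points higher from compound 1 to compound 4 (within the scatter) while phenyl and 4-methoxyphenyl both gave large rises. Nothing at hand accounts for this loss with fluoro.

As far as these compounds go, it remains open whether the high read-out of compound 3 needs methoxy specifically or would also come with ethoxy, hydroxy or an amine on this carbon. From the compounds shown here alone, it is equally open whether chloro would behave like fluoro.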